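Fluoro for methoxy carried from one core to another

The compounds below may be only part of what the source reports. "The series", "measured", "known", "first", "only" and "open" are said of these compounds alone.

Compound 1 `COc1ccc(/C=C/C(=O)C(=Cc2ccc(O)c(OC)c2)C(=O)/C=C/c2ccc(OC)cc2OC)c(OC)c1` and compound 2 `COc1ccc(/C=C/C(=O)C(=Cc2ccc(O)c(F)c2)C(=O)/C=C/c2ccc(OC)cc2OC)c(OC)c1` share one core, and compound 2 differs from compound 1 by fluoro in place of methoxy on an aromatic carbon. In a functional assay on MCF7 cells (Homo sapiens) for antiproliferative activity, read by sulforhodamine B assay, with a stated time of 48 h (on this read-out lower numbers stand for stronger inhibition and higher numbers for weaker inhibition), compound 1 gives 2140 nM, while compound 2 gives 5450 nM, so this change gives a 2.5-fold higher number from compound 1 to compound 2 (0.41 log units; beyond the scatter). Compound 3 `COc1cc(OC)c(/C=C/C(=O)C(=Cc2ccc(O)c(OC)c2)C(=O)/C=C/c2c(OC)cc(OC)cc2OC)c(OC)c1` is built on a second core, and the difference between the two cores is not broken down here. In this assay compound 3 gives 1880 nM, a number within the scatter of compound 1 and beyond the scatter against compound 2. Compound 4 `COc1cc(OC)c(/C=C/C(=O)C(=Cc2ccc(O)c(F)c2)C(=O)/C=C/c2c(OC)cc(OC)cc2OC)c(OC)c1` differs from compound 3 by fluoro in place of methoxy on an aromatic carbon, with the surroundings of the place described in the same words as before, so it is the same change seen a second time. With one earlier example to go on, compound 4 is expected to show a step of a 2.5-fold higher number from compound 3 to compound 4 (0.40 log units; beyond the scatter) in this assay because the earlier example gave a 2.5-fold higher number from compound 1 to compound 2 (0.41 log units; beyond the scatter). Compound 4 is therefore estimated at about 4700 nM, with a likely range from 2500 nM to 9000 nM.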

Compound 4, half-maximal inhibitory concentration: 3180 nM
Beside the measured number, compound 4's estimate is 1.5-fold (0.17 log units) above it; measured number inside the range.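

In this assay, replacing 4-hydroxy-3-methoxyphenyl with 3-fluoro-4-hydroxyphenyl on the second core gives a 1.7-fold higher number from compound 3 to compound 4 (0.23 log units; within the scatter), and the two cores cannot be told apart on the size of this step: the same change on two cores in this assay, a 2.5-fold higher number (0.41 log units; beyond the scatter) from compound 1 to compound 2 and a 1.7-fold higher number (0.23 log units; within the scatter) from compound 3 to compound 4, 1.5-fold (0.18 log units) apart, within the scatter of two such steps. The result is therefore compatible with the change carrying over from the core of compound 1 to the core of compound 3, although the pair on the second core does not separate from the scatter on its own. Two pairs in a single assay show no general rule for the series and do not explain the numbers.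

On these data alone, it remains open how other groups at this place, such as chloro, a nitrile or an amine, would compare with methoxy and fluoro. Also open, as far as these compounds go, is whether the step would hold on further cores or in a read-out other than this assay.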